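Half-life series: bromo for methoxy on the aromatic ring

The compounds below may be only part of what the source reports. "The series", "measured", "known", "first", "only" and "open" are said of these compounds alone.

Measured compounds:
compound 1 `COc1ccc(C[S+]([O-])c2ncccc2C(=O)Nc2ccncc2)c(OC)c1OC`: 116 h
compound 2 `COc1cc(OC)c(OC)cc1C[S+]([O-])c1ncccc1C(=O)Nc1ccncc1`: 0.14 h
compound 3 `COCOCCOc1cc(OC)ccc1C[S+]([O-])c1ncccc1C(=O)Nc1ccncc1`: 2.75 h

The three compounds were measured in an ADME assay; a lower number here means that the compound disappears faster, a higher number that the compound lasts longer. Compound 2 stands lowest of the three numbers; the nearest value is that of compound 3 and the furthest that of compound 1, both gaps beyond the scatter.

Compound 4 `COc1cc(OC)c(C[S+]([O-])c2ncccc2C(=O)Nc2ccncc2)cc1Br` has not yet been measured in this assay. Compared with compound 2 it differs by bromo in place of methoxy on an aromatic carbon; no other part of the structure changes.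

Among the compounds with values here, no single-change step between measured compounds is available to anchor the change from compound 2 to compound 4. A moderate step in this assay is expected, a 3.6-fold higher number from compound 2 to compound 4 (0.55 log units; beyond the scatter), upward, since compound 2 sits at the low end of the numbers seen so far. The half-life of compound 4 is estimated at 0.5 h, with a range from 0.1 h to 2.5 h.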

Compound 4, half-life: 28.8 h
Compound 4: middle estimate off by 58-fold (1.76 log units), on the low side, outside the stated range (above it).
By their numbers in this assay, from the lowest: compound 2; then compound 3; then compound 4; then compound 1.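

Within the data shown here, the first single-change step in this assay shows that this one aromatic position, ortho to one methoxy group and para to another, carries a very large effect: bromo in place of methoxy gives a 210-fold higher number from compound 2 to compound 4 (2.31 log units; beyond the scatter) with no other part of the structure changed. The whole step therefore belongs to this single place, where one hydrogen-bond acceptor leaves with the methoxy. Nothing at hand explains the size of the step.

On these data alone, whether chloro, methyl or a nitrile at this place would give a step of similar size remains open. Also open, as far as these compounds go, is whether bromo in place of methoxy would act the same way at the other methoxy-bearing carbons.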